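Exchanging One Halogenated Phenyl Ring for Another

This account rests on a few compounds, and the source may have more. Where it says the series, first, only, none or still open, it means among the compounds named here.

The measured compounds and their values:
compound 1, `N#Cc1cccc(Nc2ncnc3cc(NC(=O)/C=C/c4ccccc4)sc23)c1`, 15900 nM
compound 2, `COc1ccc(/C=C/C(=O)Nc2cc3ncnc(Nc4ccc(F)c(Cl)c4)c3s2)cc1`, 13900 nM
compound 3, `O=C(/C=C/c1ccccc1)Nc1cc2c(Nc3ccc(F)c(Cl)c3)ncnc2s1`, 22800 nM

All three were tested in a functional assay on HepG2 cells (Homo sapiens) for antiproliferative activity, read by MTT assay, with a stated time of 48 h; on this read-out lower numbers stand for stronger inhibition and higher numbers for weaker inhibition. Compound 3 gives the highest of the three numbers, yet its gaps to compound 1 and to compound 2 both fall within the usual scatter of repeated measurements, so the three cannot be ranked on these figures; they all sit in the same weak region of this assay. Compound 4, `O=C(/C=C/c1ccccc1)Nc1cc2c(Nc3cc(Cl)cc(Cl)c3)ncnc2s1`, has not yet been tested. It differs from compound 3 in one place: 3,5-dichlorophenyl in place of 3-chloro-4-fluorophenyl on a nitrogen on an aromatic ring. Among the compounds with values here, no pair of the measured compounds differs by a comparable exchange, so there is no measured step to lean on, and what the three known values show is only that small changes around the shared core have left the numbers close together. The most cautious view is therefore that the step from compound 3 to compound 4 will be modest, and a step that does not exceed the scatter is what is expected. For compound 4 the estimate is 18000 nM. The expected range for compound 4 is estimated to run from 6000 nM to 50000 nM. This estimate corresponds to an expected step of a 1.3-fold lower number from compound 3 to compound 4 (0.10 log units; within the scatter).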

Compound 4, half-maximal inhibitory concentration: 21800 nM
For compound 4 the middle estimate is 1.2-fold (0.08 log units) below the measured one, within the range that was stated.
By their numbers in this assay, from the lowest: compounds 2, 1, 4 and 3 (each within the scatter of the next).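

In this assay, putting 3,5-dichlorophenyl in place of 3-chloro-4-fluorophenyl on a nitrogen on an aromatic ring gives a 1.0-fold lower number from compound 3 to compound 4 (0.02 log units; within the scatter) as the only one-place step measured among these compounds. This is direct evidence that, at this position and on this core, the two halogenated phenyl rings cannot be told apart: a ring with one chlorine and one fluorine and a ring with two chlorines give readings that lie well within the scatter of each other, and both compounds stay in the same weak region of the assay. No independent measurement is available to explain this result, so the step can only be recorded as it stands.

Going by these compounds, both rings in this exchange are halogenated phenyl groups with the same count of heavy atoms, so it remains open whether a different kind of group on that nitrogen, such as a phenyl ring carrying a carboxylic acid or a dimethylamino group, would shift the number beyond the scatter. On these data alone, it also remains open whether the same exchange would read alike on the core of compound 1 or of compound 2.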